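The source may hold more compounds than are shown below. What is called first, only, known or untested is meant among the compounds shown, and "the series" means these compounds.

Compound 1, whose structure is `COc1cc(C=C(C(=O)/C=C/c2ccc(OC)c(OC)c2)C(=O)/C=C/c2ccc(OC)c(OC)c2)ccc1O`, was tested in a functional assay on A549 cells (Homo sapiens) for inhibition, read by sulforhodamine B assay, with a stated time of 48 h (a lower number here means a stronger inhibitor of growth, a higher number a weaker inhibitor of growth), where compound 1 gives 530 nM. Among the three measured compounds it has the second highest number, but the other two lie close to it: compound 2, with the structure `COc1cc(/C=C/C(=O)C(=Cc2cccc(F)c2)C(=O)/C=C/c2ccc(O)c(OC)c2)ccc1O`, gives 360 nM, and compound 3, with the structure `COc1cccc(C=C(C(=O)/C=C/c2ccc(O)c(OC)c2)C(=O)/C=C/c2ccc(O)c(OC)c2)c1`, gives 640 nM. Both of those gaps are within the scatter, so none of the three can be set apart from the others.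

The unmeasured compound 4 has the structure `COc1ccc(/C=C/C(=O)C(=Cc2ccc(C)o2)C(=O)/C=C/c2ccc(OC)c(OC)c2)cc1OC`. It differs from compound 1 in one place: 5-methylfuran-2-yl in place of 4-hydroxy-3-methoxyphenyl on a double-bonded chain carbon bound to a double-bonded chain carbon. Among the measured compounds shown here, the only measured step on a single change is the one a 1.8-fold higher number from compound 2 to compound 3 (0.25 log units; within the scatter), which swaps a substituent on the ring that sits on that same double-bonded chain carbon and stays within the scatter. For the measured compounds named here, that step does not exchange the whole ring, so it gives only weak guidance, and no measured pair shows what 5-methylfuran-2-yl does in this assay. With no evidence of a shift in either direction, the step from compound 1 to compound 4 is expected to be small, about a 1.0-fold higher number from compound 1 to compound 4 (0.02 log units; within the scatter). Compound 4 is therefore estimated at 550 nM, within a range from 200 nM to 1600 nM.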

Compound 4, concentration for 50% growth inhibition: 1310 nM
Estimate against measurement, compound 4: 2.4-fold (0.38 log units) below, within the range that was stated.
By their numbers in this assay, from the lowest: compounds 2, 1 and 3 (each within the scatter of the next); then compound 4.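

In this assay, exchanging the whole ring on the double-bonded chain carbon gives a 2.5-fold higher number from compound 1 to compound 4 (0.39 log units; beyond the scatter). Among the compounds shown here, this position therefore does respond to change, whereas the only earlier step there, a substituent swap on the ring, gave a 1.8-fold higher number from compound 2 to compound 3 (0.25 log units; within the scatter). The swap of 4-hydroxy-3-methoxyphenyl for 5-methylfuran-2-yl alters several things at once, including the ring size, the hetero atom and the hydrogen-bond donor count, and nothing available explains the shift.

As far as these compounds go, it stays open whether the furan ring, its methyl group or the loss of the hydroxy group accounts for the step. The compounds shown also leave open how this position would take an unsubstituted phenyl ring, a furan-2-yl ring without the methyl group, or a phenyl ring carrying an amine or a carboxylic acid.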